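Working notes: from compound 2 to compound 4

The source may hold more compounds than are shown below. What is called first, only, known or untested is meant among the compounds shown, and "the series" means these compounds.

Measured in a functional assay on MCF7 cells (Homo sapiens) for antiproliferative activity, read by MTT assay, with a stated time of 72 h; on this read-out lower numbers stand for stronger inhibition and higher numbers for weaker inhibition:
- compound 1 `C#CCSc1nc(Sc2nc(C)c(C)s2)c(C#N)c(-c2cc(OC)c(OC)c(OC)c2)n1`: > 20000 nM (a limit)
- compound 2 `C#CCSc1nc(Sc2ccccn2)c(C#N)c(-c2cc(OC)c(OC)c(OC)c2)n1`: > 10000 nM (a limit)
- compound 3 `C#CCSc1nc(Sc2nccs2)c(C#N)c(-c2ccc(Br)cc2)n1`: 11600 nM (a number)

Compound 2 stands only as a limit, > 10000 nM, and not as a number. Compound 1 is also only a limit, > 20000 nM, so neither compound gives a firm starting point.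

Compound 4 `C#CCSc1nc(Sc2nncs2)c(C#N)c(-c2cc(OC)c(OC)c(OC)c2)n1` has 1,3,4-thiadiazol-2-yl in place of pyridin-2-yl on a sulfur. Among the compounds with values here, the only measured step at this sulfur is a step that the two limits leave unreadable from compound 1 to compound 2, and it offers no size to carry over. Compound 3 gives 11600 nM but differs from compound 4 in more than one place, so it is only loose guidance.

No step beyond the scatter is expected in this assay because a step that the two limits leave unreadable from compound 1 to compound 2 supplies no size or direction. The expected change is a step that the limit leaves unreadable from compound 2 to compound 4 as an estimate only. Compound 4 is estimated at 15000 nM, within an expected range of 6000 nM to 40000 nM, and a report as a limit is quite likely.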

Compound 4, half-maximal inhibitory concentration: 9820 nM
For compound 4 the middle estimate is 1.5-fold (0.18 log units) above the measured one; low and high end bracket the measured number.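

Among the compounds sharing the core of compound 1 and compound 2, compound 4 is the only one that gives a number in this assay, 9820 nM, and not a limit. On this sulfur, 1,3,4-thiadiazol-2-yl gives an at least 1.0-fold lower number from compound 2 to compound 4 (0.00 log units; that floor lies within the scatter), and against 4,5-dimethyl-1,3-thiazol-2-yl it gives an at least 2.0-fold lower number from compound 1 to compound 4 (0.30 log units; that floor lies within the scatter). Both steps are floors resting on limits, so a change beyond the scatter is neither shown nor excluded at this position, and the steps that the limits leave unreadable cannot be read.

From the compounds shown here alone, how far the value would move with an open aminoethyl chain on this sulfur, in place of an aromatic ring, remains open. Going by these compounds, whether 1,3,4-thiadiazol-2-yl on the core of compound 3 would give a value different from that of compound 3 also remains open.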